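The compounds below may be only part of what the source reports. "The series", "measured", "known", "first", "only" and "open" are said of these compounds alone.

- compound 1 `O=C(COc1cccc2ccccc12)N/N=C/c1cccc(O)c1` gives 62.7 ug/mL
- compound 2 `O=C(COc1cccc2ccccc12)N/N=C/c1ccc(F)cc1` gives 71.6 ug/mL

Both numbers come from an ADME assay on HEL cells (Homo sapiens) for cytotoxicity (on this read-out higher numbers stand for lower toxicity in this test and lower numbers for higher toxicity in this test), and only these two exist so far. Compound 2 stands at 71.6 ug/mL and sits level with compound 1 within the scatter, so neither can be ranked above the other.

The next compound is compound 3 `Cc1ccc(/C=N/NC(=O)COc2cccc3ccccc23)cc1` with methyl in place of fluoro on an aromatic carbon and the rest of the molecule unchanged. Within the data shown here, no measured pair makes this exact swap, so the evidence is indirect. Among the measured compounds shown here, the only measured step is a 1.1-fold higher number from compound 1 to compound 2 (0.06 log units; within the scatter) and it comes from 4-fluorophenyl in place of 3-hydroxyphenyl, a different change at the same end of the molecule. Because a 1.1-fold higher number from compound 1 to compound 2 (0.06 log units; within the scatter) stayed within the scatter, a swap of one small group for another is not expected to move this assay much here, though one step is thin support. The expected step is a 1.1-fold lower number from compound 2 to compound 3 (0.04 log units; within the scatter) and so nothing beyond the scatter is anticipated. For compound 3 the estimated value is 66 ug/mL with an expected range from 33 ug/mL to 125 ug/mL around it.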

Compound 3, half-maximal cytotoxic concentration: 80.1 ug/mL
Beside the measured number, compound 3's estimate is 1.2-fold (0.08 log units) below it, within the range that was stated.
By their numbers in this assay, from the lowest: compounds 1, 2 and 3 (each within the scatter of the next).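

In this assay, among these compounds, methyl in place of fluoro on the aromatic carbon gives a 1.1-fold higher number from compound 2 to compound 3 (0.05 log units; within the scatter) and so provides the first direct reading at this position, para to a large group: two groups of one heavy atom each, one a carbon and one a fluorine, cannot be told apart here. Among the compounds shown here, the wider comparison of the 4-methylphenyl end with the 3-hydroxyphenyl end gives a 1.3-fold higher number from compound 1 to compound 3 (0.11 log units; within the scatter) and also stays inside the normal noise of the test, so the three ends seen so far cannot be ranked against one another, and no compound stands out as more or less toxic to these cells. Nothing measured here offers an explanation for these readings.

What the compounds shown leave open is whether an amine, a carboxylic acid or a longer chain such as butyl on this same aromatic carbon would shift the number beyond the scatter. They also leave open whether the read-out would stay this flat if the shared core itself were altered rather than this end of the molecule.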